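A few compounds are considered here, and "the series" means these few. Any claim that something is new, unique, unknown or untested is made for them only; others in the source may bear on it.

Working notes on the series. In a functional assay on Huh-7 cells (Homo sapiens) for cytotoxicity, read by CCK-8 assay, with a stated time of 72 h (a lower number here means a stronger inhibitor, a higher number a weaker inhibitor), compound 1 `C=CCn1c(=O)/c(=C\c2cccc(F)c2)[nH]c(=O)/c1=C\c1ccccc1OC` gives 27200 nM. Compound 2 `C=CCn1c(=O)/c(=C\c2cc(F)ccc2C)[nH]c(=O)/c1=C\c1ccccc1OC` gives 5600 nM, and compound 3 `C=CCn1c(=O)/c(=C\c2cccc(Br)c2)[nH]c(=O)/c1=C\c1ccccc1OC` gives 2300 nM. Compound 3 stands lowest of the three numbers: the step of a 2.4-fold lower number from compound 2 to compound 3 (0.39 log units; beyond the scatter) and the step of a 12-fold lower number from compound 1 to compound 3 (1.07 log units; beyond the scatter) both run beyond the scatter in its favour. Compound 4 `C=CCn1c(=O)/c(=C\c2ccccc2F)[nH]c(=O)/c1=C\c1ccccc1OC` is not yet measured. The change from compound 3 to compound 4 is 2-fluorophenyl in place of 3-bromophenyl on a double-bonded chain carbon bound to an aromatic carbon. The step that bears on it most directly is a 12-fold lower number from compound 1 to compound 3 (1.07 log units; beyond the scatter), a large drop in the number on exchanging fluoro for bromo; running back from bromo to fluoro, the number is expected to rise. Compound 2, which also carries a fluoro, gives 5600 nM, and the step of a 4.9-fold lower number from compound 1 to compound 2 (0.69 log units; beyond the scatter) shows how much a methyl alters a fluoro-bearing compound. Among the measured compounds shown here, no measured step moves the fluoro to the place it takes in compound 4, so the estimate leans on compound 1. Compound 4 is therefore expected near 15000 nM, within 5000 nM to 40000 nM. The step expected for compound 4 is a 6.5-fold higher number from compound 3 to compound 4 (0.81 log units; beyond the scatter), upward and beyond the scatter.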

Compound 4, half-maximal inhibitory concentration: 31300 nM
Compound 4: the middle estimate sits 2.1-fold (0.32 log units) below what was measured; the range from low to high includes it.
By their numbers in this assay, from the lowest: compound 3; then compound 2; then compounds 1 and 4 (each within the scatter of the next).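

Among the compounds shown here, the step of a 1.2-fold higher number from compound 1 to compound 4 (0.06 log units; within the scatter) shows that 2-fluorophenyl and 3-fluorophenyl on this double-bonded chain carbon cannot be told apart in this cell read-out, something the earlier compounds could not show. With a 14-fold higher number from compound 3 to compound 4 (1.13 log units; beyond the scatter) and a 5.6-fold higher number from compound 2 to compound 4 (0.75 log units; beyond the scatter), the lower numbers stay with 3-bromophenyl and 5-fluoro-2-methylphenyl, and a fluoro on the phenyl ring is not enough by itself to give them, as the fluoro of compound 2 shows. No measurement at hand gives a reason for these steps.

Bromo appears only as 3-bromophenyl, so whether the low number of compound 3 follows the bromo itself or its place on the ring stays open. Also open, as far as these compounds go, is where a phenyl carrying chloro, a nitrile or an amine at this carbon would fall relative to compound 3 and compound 4.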